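Working notes on liver microsome stability, compound 3 to compound 4

The source may hold more compounds than are shown below. What is called first, only, known or untested is meant among the compounds shown, and "the series" means these compounds.

Measured in an ADME assay on microsomes from liver (Rattus norvegicus) for metabolic stability, read by LC-MS, with a stated time of 10 min, tested at 0.5 uM; a higher number here means that more of the compound is left, a lower number that less of the compound is left:
compound 1 `CN1CCN(CCCN(C[C@H]2Cc3ccccc3CN2)[C@H]2CCCc3cccnc32)CC1`: 10%
compound 2 `c1cnc(CN(CCCN2CCNCC2)[C@H]2CCCc3cccnc32)nc1`: 68%
compound 3 `c1ccc2c(c1)CN[C@H](CN(CCCN1CCNCC1)[C@H]1CCCc3cccnc31)C2`: 88%

Compound 3 stands highest of the three numbers in this assay. Its nearest neighbour is compound 2, reached by a number 20 percentage points higher from compound 2 to compound 3 (beyond the scatter). Among the compounds with values here, the furthest is compound 1, whose value of 10% lies far beneath that of compound 3; no single-point step links these two.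

Compound 4 `c1cnc2c(c1)CN[C@H](CN(CCCN1CCNCC1)[C@H]1CCCc3cccnc31)C2` differs from compound 3 by a group of 10 heavy atoms (8 carbon, 2 nitrogen; one six-membered non-aromatic ring with 1 hetero atom, one six-membered aromatic ring with 1 hetero atom) in place of a group of 10 heavy atoms (9 carbon, 1 nitrogen; one six-membered non-aromatic ring with 1 hetero atom, one six-membered aromatic ring of carbon only), on a saturated chain carbon bound to an amine nitrogen. Within the data shown here, the only measured step at this place is a number 20 percentage points higher from compound 2 to compound 3 (beyond the scatter), which exchanged a different group, and no step exchanges one aromatic ring for another. Without a bearing step, the expectation for compound 4 is no change beyond the scatter, that is a number 3 percentage points lower from compound 3 to compound 4 (within the scatter). Compound 4 is therefore estimated at 85%, within 70% to 96%.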

Compound 4, percent of the compound remaining: 87%
Compound 4: middle estimate off by 2 percentage points, on the low side; the measured number falls inside the stated range.
By their numbers in this assay, from the lowest: compound 1; then compound 2; then compounds 4 and 3 (each within the scatter of the next).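

In this assay, an aromatic ring with 1 hetero atom in place of the aromatic ring of carbon only gives a number 1 percentage points lower from compound 3 to compound 4 (within the scatter) on the saturated chain carbon bound to an amine nitrogen, so this exchange leaves no reading beyond the scatter. The higher number over the pyrimidin-2-yl compound also holds with the new group, as a number 19 percentage points higher from compound 2 to compound 4 (beyond the scatter) shows, so it does not depend on the all-carbon aromatic ring.

On these data alone, whether any aromatic ring is needed at this place stays open, and a piperidin-2-yl group on the same carbon would address that. The data at hand give no reason for either step.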